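This account rests on a few compounds, and the source may have more. Where it says the series, first, only, none or still open, it means among the compounds named here.

Measured compounds:
- compound 1, `CCC(=O)N1N=C(C)CC1c1cc(Br)ccc1O`: "not active" (no number reported)
- compound 2, `CC1=NN(C(=O)COc2ccc(Cl)cc2)C(c2cc(Br)ccc2O)C1`: "not active" (no number reported)
- compound 3, `CC(C)CNCC(=O)N1N=C(c2cc3ccccc3oc2=O)CC1c1ccccc1`: 9970 nM

In a functional assay on HepG2 cells (Homo sapiens) for cytotoxicity, read by MTT assay, with a stated time of 48 h (on this read-out higher numbers stand for weaker inhibition and lower numbers for stronger inhibition), compound 1 is reported as "not active" (no number reported). In this assay compound 2 is likewise reported as "not active" (no number reported). Among the measured compounds shown here, compound 3 is the one member of this set with a numerical result: in this assay compound 3 gives 9970 nM, a weak effect on cell viability. For the measured compounds named here, no pair of compounds differing in a single place has been measured, so nothing is known about how any one change shifts the read-out.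

Compound 4, `CN1CCN(CC(=O)N2N=C(c3cc4ccccc4oc3=O)CC2c2ccccc2)CC1`, is built from compound 3 by a single change: 4-methylpiperazin-1-yl in place of isobutylamino on a saturated chain carbon bound to a carbonyl carbon. Going by the values given here, the change sits on the saturated chain carbon bound to the carbonyl carbon, away from the coumarin-bearing and phenyl-bearing core, and there is no measured step in this assay to show what such a change does. Among the compounds with values here, with no comparable step available, the expectation for compound 4 is that the step of a 1.0-fold higher number from compound 3 to compound 4 (0.00 log units; within the scatter) lies within the usual scatter. Compound 4 is therefore estimated at 10000 nM in this assay, with a range from 4000 nM to 25000 nM.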

Compound 4, half-maximal inhibitory concentration: 33100 nM
Estimate against measurement, compound 4: 3.3-fold (0.52 log units) below; measured number outside the range, above it.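

In this assay, among the compounds shown here, the saturated chain carbon bound to a carbonyl carbon proves to be a place where the read-out responds: 4-methylpiperazin-1-yl in place of isobutylamino gives a 3.3-fold higher number from compound 3 to compound 4 (0.52 log units; beyond the scatter), a modest step but beyond the scatter, and the first measured step in this set. On this read-out the change means weaker inhibition, so the ring-bearing group does worse here than the open-chain isobutylamino.

As far as these compounds go, it remains open whether morpholin-4-yl, dimethylamino or a carboxylic acid on this chain carbon would give a lower or a higher number than either group. From the compounds shown here alone, it also remains open whether the step would carry over to the cores of compound 1 or compound 2, which have no number to start from. Nothing measured here bears on why the number rises with this change.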